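Amine ring size across two ether variants of the core

This account rests on a few compounds, and the source may have more. Where it says the series, first, only, none or still open, it means among the compounds named here.

Compound 1 `COc1cc2ncnc(N3CCc4ccccc43)c2cc1NC(=O)/C=C/CN1CCCC1` and compound 2 `COc1cc2ncnc(N3CCc4ccccc43)c2cc1NC(=O)/C=C/CN1CCCCC1` share one core and differ only in the basic amine at the end of the side chain: piperidin-1-yl in place of pyrrolidin-1-yl on a saturated chain carbon bound to a double-bonded chain carbon. In a functional assay on PC-3 cells (Homo sapiens) for antiproliferative activity, read by MTT assay, with a stated time of 72 h (on this read-out lower numbers stand for stronger inhibition and higher numbers for weaker inhibition), compound 1 gives 2620 nM, and in this assay compound 2 gives 4180 nM, so that a 1.6-fold higher number from compound 1 to compound 2 (0.20 log units; within the scatter); the two values are within the scatter of each other and no order between them is claimed.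

Compound 3 `O=C(/C=C/CN1CCCC1)Nc1cc2c(N3CCc4ccccc43)ncnc2cc1O[C@@H]1CCOC1` carries the same side chain as compound 1 on a core that differs from it in one place: oxolan-3-yl in place of methyl on an oxygen on an aromatic ring. In this assay compound 3 gives 1510 nM, and a 1.7-fold lower number from compound 1 to compound 3 (0.24 log units; within the scatter), again within the scatter.

Compound 4 `O=C(/C=C/CN1CCCCC1)Nc1cc2c(N3CCc4ccccc43)ncnc2cc1O[C@@H]1CCOC1` is not yet measured. It differs from compound 3 by the change (piperidin-1-yl in place of pyrrolidin-1-yl on a saturated chain carbon bound to a double-bonded chain carbon), which is the same change as between compound 1 and compound 2, at a place described in the same words, now made on the core of compound 3.

Among the measured compounds shown here, the only measured instance of this change is a 1.6-fold higher number from compound 1 to compound 2 (0.20 log units; within the scatter), and nothing in these three compounds shows the two cores answering a change in the side chain differently. Compound 4 is therefore expected to give a step of a 1.6-fold higher number from compound 3 to compound 4 (0.20 log units; within the scatter) in this assay, taken from that single earlier step. For compound 4 the estimate in this assay is 2400 nM. Compound 4 is expected to fall between 1200 nM and 5000 nM, the width reflecting that the expectation rests on one measured pair and on the step of a 1.7-fold lower number from compound 1 to compound 3 (0.24 log units; within the scatter) having itself been within the scatter.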

Compound 4, half-maximal inhibitory concentration: 4510 nM
Compound 4: the middle estimate sits 1.9-fold (0.27 log units) below what was measured, within the range that was stated.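

In this assay the change from pyrrolidin-1-yl to piperidin-1-yl, made on the core of compound 3, gives a 3.0-fold higher number from compound 3 to compound 4 (0.48 log units; beyond the scatter), and the two cores cannot be told apart in their answer to it: the same change on two cores in this assay, a 1.6-fold higher number (0.20 log units; within the scatter) from compound 1 to compound 2 and a 3.0-fold higher number (0.48 log units; beyond the scatter) from compound 3 to compound 4, 1.9-fold (0.27 log units) apart, within the scatter of two such steps. The change from methyl to oxolan-3-yl on the oxygen, read with piperidin-1-yl in the side chain, gives a 1.1-fold higher number from compound 2 to compound 4 (0.03 log units; within the scatter), and its answer does not depend measurably on the side chain either: the same change on two cores in this assay, a 1.7-fold lower number (0.24 log units; within the scatter) from compound 1 to compound 3 and a 1.1-fold higher number (0.03 log units; within the scatter) from compound 2 to compound 4, 1.9-fold (0.27 log units) apart, within the scatter of two such steps. The four compounds therefore fit a change that carries from one core to the other without a readable interaction, though the amine step lies within the scatter on one core and beyond it on the other, so two pairs fix neither its size nor show that it would hold on any further core.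

Still open, going by these compounds, is whether other amines at the end of the side chain, such as morpholin-4-yl or dimethylamino, or a longer chain carrying the amine, would answer alike on both cores. Equally open, on these data alone, is whether another ether group on that oxygen, such as 2-methoxyethyl, would leave the amine step as it stands here.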